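The source may hold more compounds than are shown below. What is called first, only, known or untested is meant among the compounds shown, and "the series" means these compounds.

Measured so far in a functional assay on MCF7 cells (Homo sapiens) for cytotoxicity, read by MTT assay, with a stated time of 72 h; a lower number here means a stronger inhibitor, a higher number a weaker inhibitor:
Compound 1 `CCCCCCNc1nc(SCc2ccc(C(F)(F)F)cc2)nc2ccccc12` gives 24300 nM.
Compound 2 `FC(F)(F)c1ccc(CSc2nc(Nc3ccccc3C(F)(F)F)c3ccccc3n2)cc1` reaches only the limit of > 50000 nM, which is a limit of this assay and not a number.
Compound 3 `Cc1ccccc1Nc1nc(SCc2ccc(C(F)(F)F)cc2)nc2ccccc12` gives 37500 nM.

Compound 1 carries the lowest of the two numbers in this assay; its nearest neighbour is compound 3, and the step of a 1.5-fold higher number from compound 1 to compound 3 (0.19 log units; within the scatter) stays within the scatter, so the two are not ordered. Compound 2 sits at the limit of > 50000 nM in this assay, at which 1 of the 3 values shown sits.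

Compound 4 `O=[N+]([O-])c1cccc(Nc2nc(SCc3ccc(C(F)(F)F)cc3)nc3ccccc23)c1` is not yet measured. It differs from compound 1 in one place: 3-nitrophenyl in place of hexyl on a nitrogen on an aromatic ring.

Among the measured compounds shown here, two measured steps bear on this change, both replacing hexyl on the same nitrogen with a substituted phenyl ring: an at least 2.0-fold higher number from compound 1 to compound 2 (0.31 log units; beyond the scatter) and a 1.5-fold higher number from compound 1 to compound 3 (0.19 log units; within the scatter). Neither moves toward a lower number; one crosses the scatter upward, the other stays inside it. The step from compound 2 to compound 3, an at least 1.3-fold lower number from compound 2 to compound 3 (0.12 log units; that floor lies within the scatter), shows that the group on that phenyl ring shifts the number only within the scatter. For compound 4, a step toward a higher number in this assay is therefore expected, at most modest in size, and a limit rather than a number is a real possibility.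

Compound 4 is estimated at 40000 nM, within a range from 20000 nM to 80000 nM, which would mean an expected step of a 1.6-fold higher number from compound 1 to compound 4 (0.22 log units; within the scatter).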

Compound 4, half-maximal inhibitory concentration: > 50000 nM
Compound 4: no number, only a limit; the forecaster's own chance of this, stated with the estimate: 35%; middle value at least 1.2-fold (0.09 log units) away from the limit.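

In this assay compound 4 gives > 50000 nM, which is a limit of the assay and not a number. The change from hexylamino to (3-nitrophenyl)amino gives an at least 2.0-fold higher number from compound 1 to compound 4 (0.31 log units; beyond the scatter), so a second substituted phenyl ring on this nitrogen now crosses the scatter upward, while compound 3 goes against any general pattern with a 1.5-fold higher number from compound 1 to compound 3 (0.19 log units; within the scatter). Compound 3 and compound 4 are not ordered, as an at least 1.3-fold higher number from compound 3 to compound 4 (0.12 log units; that floor lies within the scatter) has a floor within the scatter, and the step between compound 2 and compound 4 cannot be read, leaving the two substituted phenyl rings that reach the limit unranked against each other: the limit of > 50000 nM in this assay, at which 2 of the 4 values shown sit.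

Open, on these data alone, is whether the step belongs to the phenyl ring itself or to the groups it carries, a question that a plain phenyl ring on this nitrogen would address. Also open, as far as these compounds go, is whether any group here can go lower than hexyl in this assay, for instance a shorter chain such as butyl, a longer chain, or a chain ending in an amine or a carboxylic acid.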